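The compounds below may be only part of what the source reports. "The series", "measured", "known", "first", "only" and "open" are said of these compounds alone.

Values in a physicochemical assay for solubility, measured as kinetic solubility, with a stated time of 1 h, at pH 7.4; on this read-out lower numbers stand for lower solubility and higher numbers for higher solubility
- compound 1 `CC(=O)Nc1nc(-c2ccc(F)c(Cl)c2)cs1` gives 10000 nM
- compound 2 `N#CCC(=O)Nc1cc(-c2ccc(Cl)c(Cl)c2)cs1` gives 12000 nM
- compound 3 `O=C(NC1=NN(c2ccc(Cl)c(Cl)c2)CC1)c1ccncc1` gives 9000 nM

On these numbers, compound 3 at 9000 nM stands within the scatter of both compound 1 and compound 2, so the three values do not separate. The next structure is compound 4 `Cc1ncncc1C(=O)NC1=NN(c2ccc(Cl)c(Cl)c2)CC1`, which carries 4-methylpyrimidin-5-yl in place of pyridin-4-yl on a carbonyl carbon. Within the data shown here, no measured pair differs in one place only, so the data offer no direct guide to this change. In this assay no step beyond the scatter is expected, and no direction is favoured. The estimated step of a 1.2-fold higher number from compound 3 to compound 4 (0.09 log units; within the scatter) is therefore expected to be small. For compound 4 the estimated value is 11000 nM, with an expected range of 5000 nM to 25000 nM for the coming measurement.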

Compound 4, solubility: 12000 nM
The estimate for compound 4 lay 1.1-fold (0.04 log units) below the measured number; low and high end bracket the measured number.
By their numbers in this assay, from the lowest: compounds 3, 1, 2 and 4 (each within the scatter of the next).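

In this assay, among these compounds, the step of a 1.3-fold higher number from compound 3 to compound 4 (0.12 log units; within the scatter) gives the first comparison that differs in one place only. On a carbonyl carbon whose other neighbour is an amide-type nitrogen, 4-methylpyrimidin-5-yl in place of pyridin-4-yl therefore leaves the two compounds unseparated. No measured data bear on why this result arises.

Still open, on these data alone, is how a non-aromatic group at this place, such as a morpholine or a carboxylic acid, would read out. As far as these compounds go, with a single pair, it also remains open whether other aromatic rings at this place would stay within the scatter.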